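The source may report more compounds than this note shows. Statements on the series, on what has been measured and on what is new or still open speak of the compounds shown alone.

Measured in a functional assay with Oryctolagus cuniculus as the target; a lower number here means a stronger inhibitor, a higher number a weaker inhibitor:
- Compound 1 `CCN(CC)C(=O)c1nc(-c2ccc(OC)cc2)c(-c2ccc(OC)cc2)s1`: < 10 nM (a limit)
- Compound 2 `COc1ccc(-c2nc(C(=O)N3CCOCC3)sc2-c2ccc(OC)cc2)cc1`: < 10 nM (a limit)

Compound 2 stands at < 10 nM in this assay, which is a limit of the assay and not a number. The same holds for both measured compounds, as the record shows (the limit of < 10 nM in this assay, at which 2 of the 2 values shown sit). Compound 3 `COc1ccc(-c2nc(C(=O)N3CCCCC3)sc2-c2ccc(OC)cc2)cc1` carries piperidin-1-yl in place of morpholin-4-yl on a carbonyl carbon. Among the compounds with values here, the only measured step that bears on this change sits on the same carbonyl carbon, and it is a step that the two limits leave unreadable from compound 1 to compound 2. It therefore gives no size to carry over. No step beyond the scatter is expected in this assay, and no direction can be assigned, though the data cannot exclude either. The expected step is a step that the limit leaves unreadable from compound 2 to compound 3. For compound 3 the estimated value is 5 nM, with an expected range from 1 nM to 30 nM.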

Compound 3, half-maximal inhibitory concentration: > 1000 nM
Compound 3 ended at the assay's limit (the forecaster's own chance of this, stated with the estimate: 70%); middle value at least 200-fold (2.30 log units) away from the limit.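

In this assay, the carbonyl carbon proves to be a place where a single change matters, with an at least 100-fold higher number from compound 2 to compound 3 (2.00 log units; beyond the scatter), even though piperidin-1-yl only puts a ring carbon where morpholin-4-yl has its oxygen, at the same heavy-atom count. The value of compound 3 is a limit of the assay and not a number: the limit of > 1000 nM in this assay, at which 1 of the 3 values shown sits. Piperidin-1-yl in place of diethylamino gives an at least 100-fold higher number from compound 1 to compound 3 (2.00 log units; beyond the scatter), so compound 1 goes against any reading that the loss of the ring oxygen alone separates these compounds, for diethylamino has no such oxygen either.

On these data alone, the step from compound 1 to compound 2 cannot be read, and the full size of the two large steps stays unknown. As far as these compounds go, whether pyrrolidin-1-yl or 4-methylpiperazin-1-yl on the same carbonyl carbon would fall with compound 2 or with compound 3 remains open.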